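Replacing 4-hydroxyphenyl with thiophen-2-yl on a shared core

A few compounds are considered here, and "the series" means these few. Any claim that something is new, unique, unknown or untested is made for them only; others in the source may bear on it.

Three measured compounds share one core and differ in a single aromatic group. Compound 1 `COc1ccc(S(=O)(=O)N2CCc3cccc(-c4ccco4)c32)cc1` carries furan-2-yl, compound 2 `COc1ccc(S(=O)(=O)N2CCc3cccc(-c4ccccc4)c32)cc1` carries phenyl and compound 3 `COc1ccc(S(=O)(=O)N2CCc3cccc(-c4ccc(O)cc4)c32)cc1` carries 4-hydroxyphenyl. In a functional assay on KB-VIN10 cells (Homo sapiens) for inhibition, with a stated time of 72 h (on this read-out lower numbers stand for stronger inhibition and higher numbers for weaker inhibition), compound 1 gives 79.2 nM as its result, compound 2 gives 107 nM and compound 3 gives 123 nM on the same scale. Compound 3 therefore stands level with the other two: the steps to it are a 1.1-fold higher number from compound 2 to compound 3 (0.06 log units; within the scatter) and a 1.6-fold higher number from compound 1 to compound 3 (0.19 log units; within the scatter) and neither separates the pair. The remaining step, a 1.4-fold higher number from compound 1 to compound 2 (0.13 log units; within the scatter), tells the same story.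

Compound 4 `COc1ccc(S(=O)(=O)N2CCc3cccc(-c4cccs4)c32)cc1` comes from compound 3 through one change thiophen-2-yl in place of 4-hydroxyphenyl on an aromatic carbon with thiophen-2-yl in place of 4-hydroxyphenyl on an aromatic carbon. For the measured compounds named here, no measured compound here carries thiophen-2-yl yet. Its five-membered aromatic ring resembles the furan-2-yl of compound 1, so the closest guide is a 1.6-fold higher number from compound 1 to compound 3 (0.19 log units; within the scatter) read backwards. All three swaps so far stayed small, so no step beyond the scatter is expected in this assay for this one. The expected move is a 1.4-fold lower number from compound 3 to compound 4 (0.15 log units; within the scatter) and that remains an estimate. For compound 4 the estimated value is 88 nM with an expected range from 45 nM to 170 nM on this read-out.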

Compound 4, half-maximal inhibitory concentration: 251 nM
The estimate for compound 4 lay 2.9-fold (0.46 log units) below the measured number; the whole stated range lies below it.
By their numbers in this assay, from the lowest: compounds 1, 2 and 3 (each within the scatter of the next); then compound 4.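

At this position on the shared core, the choice of aromatic group can matter after all: in this assay, thiophen-2-yl produces the first differences beyond the scatter, with (a 2.0-fold higher number from compound 3 to compound 4 (0.31 log units; beyond the scatter)) , (a 2.3-fold higher number from compound 2 to compound 4 (0.37 log units; beyond the scatter)) and (a 3.2-fold higher number from compound 1 to compound 4 (0.50 log units; beyond the scatter)) against the three earlier compounds. This makes compound 4 the weakest of the four, while furan-2-yl, phenyl and 4-hydroxyphenyl remain within the scatter of one another, so a five-membered aromatic ring alone does not set the result, and furan-2-yl and thiophen-2-yl cannot be treated as interchangeable here. No measurement is available to explain this difference.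

The compounds shown leave open whether the change follows from the sulfur atom itself or from how the ring is attached to the core, a question that thiophen-3-yl could help to separate. From the compounds shown here alone, it also remains open how groups of a different kind, such as an amine or a carboxylic acid, would behave at this position in this assay on the same core.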